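The compounds below may be only part of what the source reports. "The series", "measured", "known", "first", "only" and "open" are said of these compounds alone.

In an ADME assay for permeability (a higher number here means that the compound crosses the layer faster, a lower number that the compound crosses the layer more slowly), compound 3 (`CNC(=O)c1cc(C(=O)NC(C)CO)n([C@@H](C)c2ccccc2)n1`) gives 120 nm/s. Compound 1 (`CNC(=O)c1cc(C(=O)N[C@H]2CC[C@H](O)CC2)n([C@@H](C)c2ccccc2)n1`) gives 80 nm/s, which lies within the scatter of compound 3. Compound 2 (`CNC(=O)c1cc(C(=O)N[C@H]2CC[C@H](OC)CC2)n([C@@H](C)c2ccccc2)n1`) gives 360 nm/s and stands clear of that pair, with a 3.0-fold lower number from compound 2 to compound 3 (0.48 log units; beyond the scatter).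

Compound 4 (`CNC(=O)c1cc(C(=O)N[C@H]2[C@@H]3C[C@@H](O)C[C@@H]32)n([C@@H](C)c2ccccc2)n1`) keeps the shared core and changes only the group on the amide-type nitrogen: a group of 7 heavy atoms (6 carbon, 1 oxygen; one three-membered non-aromatic ring of carbon only, one five-membered non-aromatic ring of carbon only) in place of a group of 4 heavy atoms (3 carbon, 1 oxygen; no ring), on an amide-type nitrogen.

Among the compounds with values here, two measured steps bear on this change. The closest is the other exchange of a hydroxyl-bearing group at this nitrogen, a 1.5-fold higher number from compound 1 to compound 3 (0.18 log units; within the scatter), which stays within the scatter. The second, a 4.5-fold higher number from compound 1 to compound 2 (0.65 log units; beyond the scatter), is the only modest rise and comes with methyl in place of hydrogen on the oxygen. Compound 4 has no such methyl, so that step is not expected to apply.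

The expected step is a 1.2-fold lower number from compound 3 to compound 4 (0.08 log units; within the scatter), and no change beyond the scatter is expected in this assay. For compound 4 the estimated value is 100 nm/s, with an expected range of 50 nm/s to 200 nm/s.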

Compound 4, apparent permeability: 61 nm/s
Estimate against measurement, compound 4: 1.6-fold (0.21 log units) above, within the range that was stated.
By their numbers in this assay, from the lowest: compounds 4, 1 and 3 (each within the scatter of the next); then compound 2.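

On the amide-type nitrogen, the group of 7 heavy atoms with a three-membered and a five-membered ring gives a 2.0-fold lower number from compound 3 to compound 4 (0.29 log units; within the scatter) and a 1.3-fold lower number from compound 1 to compound 4 (0.12 log units; within the scatter) in this assay, so it stays within the scatter of both the open-chain 1-(hydroxymethyl)ethyl and the 4-hydroxycyclohexyl groups. Among compounds 1, 3 and 4, changing this group therefore moves the number by no more than the scatter, while compound 2 goes against that pattern, with a 5.9-fold lower number from compound 2 to compound 4 (0.77 log units; beyond the scatter). No supporting data account for these differences.

Still open, as far as these compounds go, is whether methyl on the oxygen of the compound 4 group would produce a rise like a 4.5-fold higher number from compound 1 to compound 2 (0.65 log units; beyond the scatter). Also open, from the compounds shown here alone, is how an amine or a carboxylic acid in place of the hydroxyl would read in this assay.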